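The source may report more compounds than this note shows. Statements on the series, on what has been measured and on what is new or still open speak of the compounds shown alone.

Measured in a functional assay on IMR-32 cells (Homo sapiens) for cytotoxicity, read by sulforhodamine B assay, with a stated time of 48 h; a higher number here means a weaker inhibitor, a lower number a stronger inhibitor
- compound 1 `C=CCOc1ccc(F)cc1C(=O)c1cccnc1` gives 91000 nM
- compound 2 `C=CCOc1cc(Br)ccc1C(=O)c1cccnc1` gives 98000 nM
- compound 3 `C=CCOc1ccc(Cl)cc1C(=O)c1cccnc1` gives 91000 nM

Compound 3 stands level with compound 1 and within the scatter of compound 2. Compound 4 `C=CCOc1ccccc1C(=O)c1cccnc1` carries hydrogen in place of chloro on an aromatic carbon. Within the data shown here, one measured step bears on this: no change at the digits printed from compound 1 to compound 3 (within the scatter) on that same carbon, a swap of one halogen for another. Among the measured compounds shown here, no measured step removes the halogen altogether, so the evidence is indirect. In this assay no step beyond the scatter is expected, and no direction is favoured. The expected step is a 1.1-fold higher number from compound 3 to compound 4 (0.04 log units; within the scatter) on this estimate. For compound 4 the estimated value is 100000 nM with an expected range from 55000 nM to 180000 nM overall.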

Compound 4, half-maximal inhibitory concentration: 44000 nM
Estimate against measurement, compound 4: 2.3-fold (0.36 log units) above; measured number outside the range, below it.
By their numbers in this assay, from the lowest: compound 4; then compounds 1, 3 and 2 (each within the scatter of the next).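

In this assay the halogens stayed within the scatter of one another, but hydrogen in place of halogen registers as a 2.1-fold lower number from compound 3 to compound 4 (0.32 log units; beyond the scatter) and a 2.1-fold lower number from compound 1 to compound 4 (0.32 log units; beyond the scatter) and a 2.2-fold lower number from compound 2 to compound 4 (0.35 log units; beyond the scatter), all three modest. Within this set, the presence or absence of a halogen separates compound 4 from the others, and the identity of the halogen does not. Nothing measured here accounts for this step. Still open, as far as these compounds go, is whether an amine or a carboxylic acid on the same aromatic carbon would sit with the halogens or with hydrogen. Also open, from the compounds shown here alone, is whether the step persists with a longer chain in place of the allyloxy group.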